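The source may report more compounds than this note shows. Statements on the series, on what has been measured and on what is new or still open speak of the compounds shown alone.

Compound 1 `CC1=CC[C@@H]([C@@](C)(O)CCCC(C)(C)NC(=S)N/N=C\c2ccc(C)cc2)CC1` gives 52300 nM
Compound 2 `CC1=CC[C@@H]([C@@](C)(O)CCCC(C)(C)NC(=S)N/N=C\c2cccc([N+](=O)[O-])c2)CC1` gives 49300 nM

Both numbers come from a functional assay on UACC-62 cells (Homo sapiens) for cytotoxicity, read by sulforhodamine B assay (on this read-out lower numbers stand for higher toxicity in this test and higher numbers for lower toxicity in this test), and lie within the usual scatter of each other, so compound 1 cannot be told apart from compound 2 on this evidence. Compound 3 `CC1=CC[C@@H]([C@@](C)(O)CCCC(C)(C)NC(=S)N/N=C(/C)c2ccccc2)CC1`, not yet measured, has the same atoms as compound 1, joined differently, and a group of 9 heavy atoms (8 carbon, 1 nitrogen; one six-membered aromatic ring of carbon only) in place of a group of 9 heavy atoms (8 carbon, 1 nitrogen; one six-membered aromatic ring of carbon only), on an amide-type nitrogen is the change to follow. Among the measured compounds shown here, only one measured step bears on it: a 1.1-fold lower number from compound 1 to compound 2 (0.03 log units; within the scatter) stays within the scatter. That step is a different change from this one, so the support is thin. On that single step, no shift beyond the scatter is expected in this assay here. The estimated step is a 1.1-fold lower number from compound 1 to compound 3 (0.04 log units; within the scatter) at the middle of the range. For compound 3 the expected value is 48000 nM with an estimated range of 22000 nM to 100000 nM as the likely span.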

Compound 3, concentration lethal to 50% of the cells: > 100000 nM
Compound 3 ended at the assay's limit (the forecaster's own chance of this, stated with the estimate: 10%); middle value at least 2.0-fold (0.31 log units) away from the limit.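

In this assay, rejoining the same atoms in the group on the amide-type nitrogen gives an at least 1.9-fold higher number from compound 1 to compound 3 (0.28 log units; that floor lies within the scatter). Among the compounds shown here, the value of compound 3 is a limit of the assay and not a number, so the true size of this step cannot be read: the limit of > 100000 nM in this assay, at which 1 of the 3 values shown sits. Compounds 1 and 2 both gave measured numbers, whereas this rearrangement reaches the limit of this assay, which is the first hint that this group may matter, though the floor of the step still lies within the scatter.

As far as these compounds go, whether compound 3 truly differs from compound 1 therefore stays open. Also open, from the compounds shown here alone, is how a different group at this place would read, such as one carrying an amine or a carboxylic acid on the aromatic ring.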